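Removing Fluorines: The Step from Compound 2 to Compound 3

This account rests on a few compounds, and the source may have more. Where it says the series, first, only, none or still open, it means among the compounds named here.

Within the data shown here, of the two compounds measured so far in a functional assay on MCF7 cells (Homo sapiens) for inhibition, read by MTT assay, with a stated time of 48 h, tested at 10 uM (a lower number here means less inhibition of growth, a higher number more inhibition of growth at the concentration tested), compound 2 `CN1CC[C@H](c2c(O)cc(O)c3c(=O)cc(/C=C/c4c(F)c(F)c(F)c(F)c4F)oc23)[C@H](O)C1` stands highest, with 64%, while compound 1 `CN1CC[C@H](c2c(O)cc(O)c3c(=O)cc(/C=C/c4ccccc4)oc23)[C@H](O)C1` gives 8%. The next compound, compound 3 `CN1CC[C@H](c2c(O)cc(O)c3c(=O)cc(/C=C/c4ccccc4F)oc23)[C@H](O)C1`, keeps the shared core and differs from compound 2 in one group: 2-fluorophenyl in place of 2,3,4,5,6-pentafluorophenyl on a double-bonded chain carbon bound to a double-bonded chain carbon.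

Among the measured compounds shown here, only one measured step bears on this change. It is a number 56 percentage points higher from compound 1 to compound 2 (beyond the scatter), a large step that replaces phenyl with 2,3,4,5,6-pentafluorophenyl at the same place. In its fluorine content, the 2-fluorophenyl group of compound 3 falls between the groups of compound 1 and compound 2, but the data do not show how that large step divides among the fluorines. With so little fluorine left, most of the gain is expected to be lost, so the expected change is a number 44 percentage points lower from compound 2 to compound 3 (beyond the scatter), a large fall beyond the scatter. For compound 3 the estimated value in this assay is 20%, with an expected range from 5% to 42%.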

Compound 3, percent growth inhibition at one concentration: 62%
Compound 3: middle estimate off by 42 percentage points, on the low side; the whole stated range lies below it.
By their numbers in this assay, from the lowest: compound 1; then compounds 3 and 2 (each within the scatter of the next).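

In this assay the step of a number 2 percentage points lower from compound 2 to compound 3 (within the scatter) shows that, on a double-bonded chain carbon bound to a double-bonded chain carbon, the 2-fluorophenyl group and the 2,3,4,5,6-pentafluorophenyl group cannot be told apart, although one carries a single fluorine and the other five. The step of a number 54 percentage points higher from compound 1 to compound 3 (beyond the scatter), with fluoro in place of hydrogen on an aromatic carbon, shows that the large difference from phenyl, seen earlier only with all five fluorines in place, already appears with one fluorine in this set of three compounds. The information given here offers no explanation of why one fluorine and five give readings within the scatter of each other.

As far as these compounds go, it remains open whether this gain over compound 1 is particular to fluoro or would also appear with a chloro or a methoxy group on the phenyl ring. Also unresolved is whether compound 2 and compound 3 would stay within the scatter of each other at concentrations other than the single one used in this assay.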